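The source may report more compounds than this note shows. Statements on the series, on what has been measured and on what is new or still open speak of the compounds shown alone.

Working notes on three measured compounds and one still open, all built on the shared core. Compound 1 `O=C(Nc1cccc(-c2ccoc2)c1)C(Cl)Cl`, compound 2 `O=C(Nc1cccc(-c2cccc(F)c2)c1)C(Cl)Cl` and compound 3 `COC(=O)c1ccc(-c2cccc(NC(=O)C(Cl)Cl)c2)cc1` were run in a functional assay on KB 3-1 cells (Homo sapiens) for cytotoxicity, read by MTT assay, with a stated time of 68 h; a higher number here means a weaker inhibitor, a lower number a stronger inhibitor. Compound 1 returns only a limit of the assay, > 50000 nM, and not a number. Compound 2 likewise returns only a limit, > 50000 nM. Compound 3 returns a limit as well, > 50000 nM. Where compound 2 stands is therefore known only as a limit, and the same holds for the other two values shown: the limit of > 50000 nM in this assay, at which 3 of the 3 values shown sit. Among the measured compounds shown here, no measured pair differs in a single place, so no measured step exists whose size could be set against the scatter.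

Compound 4 `Cc1cccc(-c2cccc(NC(=O)C(Cl)Cl)c2)c1` is the open compound. It departs from compound 2 by methyl in place of fluoro on an aromatic carbon. With every measured value sitting at the limit, the expected step in this assay is a step that the limit leaves unreadable from compound 2 to compound 4, a change of no more than the scatter, and the most likely outcome is again a limit rather than a number. The estimate for compound 4 in this assay is 60000 nM, with a range from 20000 nM to 200000 nM.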

Compound 4, half-maximal inhibitory concentration: > 50000 nM
Compound 4 gave a limit, no number; the forecaster's own chance of this, stated with the estimate: 80%; the middle value is on the limit's open side.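

In this assay compound 2 and compound 4 both give only a limit, so no step can be read for methyl in place of fluoro on an aromatic carbon. All values shown stand together: the limit of > 50000 nM in this assay, at which 4 of the 4 values shown sit. From the compounds shown here alone, whether any change to the shared core brings a number in this assay remains open.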